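Replacing methoxy with chloro on compound 3

This account rests on a few compounds, and the source may have more. Where it says the series, first, only, none or still open, it means among the compounds named here.

Compound 1 `CC[C@@H](CCn1cncn1)c1ccc(C)cc1`: 69.9 ug/mL
Compound 2 `CCCC[C@@H](CCn1cncn1)c1ccc(Cl)cc1Cl`: 6.5 ug/mL
Compound 3 `COc1ccc([C@H](CCn2cncn2)Cc2ccccc2)cc1`: 60.3 ug/mL

In an ADME assay on HEp-2 cells (Homo sapiens) for cytotoxicity, read by MTT assay, with a stated time of 3 days (on this read-out higher numbers stand for lower toxicity in this test and lower numbers for higher toxicity in this test), compound 3 gives 60.3 ug/mL, the second highest of the three numbers. It lies within the usual scatter of compound 1 and well clear of compound 2.

Compound 4 `Clc1ccc([C@H](CCn2cncn2)Cc2ccccc2)cc1` has chloro in place of methoxy on an aromatic carbon, para to a large group: chloro in place of methoxy on an aromatic carbon.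

Among the measured compounds shown here, no measured pair isolates this change. For the measured compounds named here, compound 2, the only measured compound carrying chloro, gives 6.5 ug/mL, but it differs from compound 3 in more than one place. A moderate drop beyond the scatter in this assay is therefore expected, pointing to higher toxicity. The expected size is a 2.4-fold lower number from compound 3 to compound 4 (0.38 log units; beyond the scatter). Compound 4 is estimated at 25 ug/mL, with an expected range of 10 ug/mL to 55 ug/mL.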

Compound 4, half-maximal cytotoxic concentration: 25.7 ug/mL
Estimate against measurement, compound 4: 1.0-fold (0.01 log units) below, and the stated range covers the measured number.
By their numbers in this assay, from the lowest: compound 2; then compound 4; then compounds 3 and 1 (each within the scatter of the next).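

Among the compounds shown here, compound 3 and compound 4 are the only pair here that differ in one place, and in this assay they give a 2.3-fold lower number from compound 3 to compound 4 (0.37 log units; beyond the scatter) as the sole change. For the compounds shown here, this shows that the aromatic carbon para to a large group responds to chloro in place of methoxy, with the lower number standing for higher toxicity in this test, which the earlier compounds, differing in several places, could not show. No measurement here accounts for the shift.

On these data alone, whether an amine or a carboxylic acid on the same carbon would move the number in the same direction stays open. So does whether this change would give a similar step on a compound with a different chain.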